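Swapping the aniline substituents on a pyrimidinyl urea core

A few compounds are considered here, and "the series" means these few. Any claim that something is new, unique, unknown or untested is made for them only; others in the source may bear on it.

Compound 1 `COc1ccc(F)cc1Nc1cc(NC(=O)Nc2c(Cl)cccc2Cl)ncn1` gives 85.5% in a functional assay on PC-9 cells (Homo sapiens) for inhibition, read by MTT assay, with a stated time of 48 h, tested at 10 uM; on this read-out lower numbers stand for less inhibition and higher numbers for more inhibition at the one concentration tested (going by the name of the read-out).
Compound 2 `COc1cc(NC(=O)Nc2cc(Nc3ccc(C)c(C)c3)ncn2)cc(OC)c1` gives 66% in this assay.
Compound 3 `COc1cc(NC(=O)Nc2cc(Nc3ccc(C)c(F)c3)ncn2)cc(OC)c1` gives 77.5% in this assay.

Compound 3 stands second highest of the three: compound 1 lies within the scatter of it, while compound 2 sits below it by a number 11.5 percentage points higher from compound 2 to compound 3 (beyond the scatter). Compound 4 `COc1cc(NC(=O)Nc2cc(Nc3cc(Br)ccc3OC)ncn2)cc(OC)c1` carries 5-bromo-2-methoxyphenyl in place of 3-fluoro-4-methylphenyl on a nitrogen on an aromatic ring. Going by the values given here, the one measured step, a number 11.5 percentage points higher from compound 2 to compound 3 (beyond the scatter), concerns a different exchange on that same ring and does not reach the present change; compound 1, which also carries a methoxy group on that part, gives 85.5%. With so little to go on, compound 4 is expected to land near compound 3, the step of a number 0.5 percentage points higher from compound 3 to compound 4 (within the scatter) being expected within the scatter. Compound 4 is therefore estimated at 78%, between 64% and 90%.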

Compound 4, a percentage reported as inhibition, at one concentration (the size of the read-out at that concentration, not a potency): 82.5%
Compound 4: the middle estimate sits 4.5 percentage points below what was measured; low and high end bracket the measured number.
By their numbers in this assay, from the lowest: compound 2; then compounds 3, 4 and 1 (each within the scatter of the next).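

On a nitrogen on an aromatic ring, 5-bromo-2-methoxyphenyl in place of 3-fluoro-4-methylphenyl gives a number 5 percentage points higher from compound 3 to compound 4 (within the scatter) in this assay, so two aryl groups with different substituents can stand here with no change beyond the usual scatter. Going by these compounds alone, in place of 3,4-dimethylphenyl, the same group gives a number 16.5 percentage points higher from compound 2 to compound 4 (beyond the scatter), a step that the earlier compounds did not show for this group. No measurement shown here explains either step.

The compounds shown leave open whether the bromine or the methoxy group matters more, as the two enter together. As far as these compounds go, what a morpholine or a carboxylic acid on this aryl ring would do also remains open.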